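The source may report more compounds than this note shows. Statements on the series, on what has been measured and on what is new or still open speak of the compounds shown alone.

Measured so far:
Compound 1 `CC1(C)C=C(n2ccccc2=O)c2cc(C(=O)c3ccccc3F)ccc2O1` — 6.34
Compound 2 `CC1(C)C=C(n2ccccc2=O)c2cc(C(=O)c3ccccc3C(F)(F)F)ccc2O1` — 5.78

Both compounds were tested in a functional assay (trachea) with Rattus norvegicus as the target; a higher number here means a more potent compound, by a factor of ten per unit of this negative logarithm, a lower number a less potent compound. For the measured compounds named here, compound 2 is the lower of the two numbers, and the only step known is a number 0.56 log units lower from compound 1 to compound 2 (beyond the scatter), so trading fluoro for trifluoromethyl cost potency by a modest but real margin.

Compound 3 `CC1(C)C=C(n2ccccc2=O)c2cc(C(=O)c3c(F)cccc3F)ccc2O1` has not yet been measured. It differs from compound 2 by 2,6-difluorophenyl in place of 2-(trifluoromethyl)phenyl on a carbonyl carbon. Going by the values given here, this is, in effect, a return to the fluoro-bearing ring of compound 1, with fluoro now present as 2,6-difluorophenyl instead of the single fluoro of compound 1. Among the compounds with values here, the one step that bears on this change is the loss seen in a number 0.56 log units lower from compound 1 to compound 2 (beyond the scatter); reversing the trifluoromethyl-to-fluoro exchange would be expected to recover roughly that amount. No measurement shows what the second fluoro itself adds or removes, so the estimate rests on compound 1 alone.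

Compound 3 is therefore expected to rise relative to compound 2 by about a number 0.52 log units higher from compound 2 to compound 3 (beyond the scatter), landing near the value of compound 1. The estimate for compound 3 in this assay is 6.3, with a range from 5.8 to 6.8.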

Compound 3, logarithm of the reciprocal of the active concentration, log(1/C): 5.99
For compound 3 the middle estimate is 0.31 log units above the measured one; low and high end bracket the measured number.
By their numbers in this assay, from the lowest: compounds 2 and 3 (each within the scatter of the next); then compound 1.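

In this assay, exchanging 2-(trifluoromethyl)phenyl for 2,6-difluorophenyl on the carbonyl carbon gives a number 0.21 log units higher from compound 2 to compound 3 (within the scatter) and so does not separate these two groups, even though both differ from the ring of the best compound shown. The new compound also gives the first direct view of fluoro in place of hydrogen on this ring: the step reads a number 0.35 log units lower from compound 1 to compound 3 (beyond the scatter) and shows that a second fluoro did not add potency here, leaving compound 1 above both other compounds by more than the scatter. Nothing available explains why the single fluoro gives the highest number of the three, and the data offer no measured property of these groups that could account for it.

All three rings shown carry only fluoro or trifluoromethyl, so it remains open how this position responds to a group of a different kind, such as methoxy, an amine or a carboxylic acid. For the compounds shown here, the compounds also leave open how a plain phenyl with no substituent would compare, which would show whether the single fluoro of compound 1 helps at all.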